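Replacing the carboxy group in a pyrazolone benzimidazole series

A few compounds are considered here, and "the series" means these few. Any claim that something is new, unique, unknown or untested is made for them only; others in the source may bear on it.

Measured so far:
- compound 1 `Cc1[nH]n(-c2nc3ccccc3[nH]2)c(=O)c1CC(=O)O`: 15000 nM
- compound 2 `Cc1ccc2[nH]c(-n3[nH]c(C)c(Cc4ccc(Cl)cc4)c3=O)nc2c1`: 750 nM
- compound 3 `Cc1[nH]n(-c2nc3ccccc3[nH]2)c(=O)c1Cc1ccc(-c2ccccc2)cc1`: 720 nM

In an assay on isolated protein for inhibition of alpha-ketoglutarate-dependent dioxygenase alkB homolog 3 (Homo sapiens), read by polymerase chain reaction, with a stated time of 1 h (a higher number here means a weaker inhibitor, a lower number a stronger inhibitor), compound 1 gives the highest of the three numbers; compound 2 and compound 3 both sit far lower, beyond the scatter. Compound 2 and compound 3 lie within the scatter of each other. Compound 4 `Cc1[nH]n(-c2nc3ccccc3[nH]2)c(=O)c1Cc1ccccc1Cl` has not yet been tested. It differs from compound 1 by 2-chlorophenyl in place of carboxy on a saturated chain carbon bound to an aromatic carbon. Going by the values given here, no measured pair shows this exact change, but related substituted benzyl groups stand in place of carboxymethyl in compound 2, which gives 750 nM, and in compound 3, which gives 720 nM. On that basis a large step downward is expected from compound 1 to compound 4, a 15-fold lower number from compound 1 to compound 4 (1.18 log units; beyond the scatter). Compound 4 is estimated at 1000 nM, within 300 nM to 4000 nM in this assay.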

Compound 4, half-maximal inhibitory concentration: > 10000 nM
Compound 4 gave a limit, no number (the forecaster's own chance of this, stated with the estimate: 5%); middle value at least 10-fold (1.00 log units) away from the limit.
By their numbers in this assay, from the lowest: compounds 3 and 2 (each within the scatter of the next); then compound 1.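

Compound 4 returns > 10000 nM, a limit and not a number, so the step from compound 1 to compound 4 cannot be read. The compounds shown leave open whether 2-chlorobenzyl in place of carboxymethyl changes the number at all.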